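This account rests on a few compounds, and the source may have more. Where it says the series, first, only, none or still open, it means among the compounds named here.

In an ADME assay on Vero 76 cells (Chlorocebus sabaeus) for cytotoxicity, read by crystal violet staining, with a stated time of 96 h (on this read-out higher numbers stand for lower toxicity in this test and lower numbers for higher toxicity in this test), three compounds that share one core have been measured so far. Compound 1 `O=[N+]([O-])c1ccc(NC(=S)Nc2cccc(C(F)(F)F)c2)cc1` gives 10000 nM in this test, compound 2 `N#Cc1ccc(NC(=S)Nc2cccc(C(F)(F)F)c2)cc1` gives 10000 nM in this test, and compound 3 `Cc1ccc(NC(=S)Nc2cccc(C(F)(F)F)c2)cc1Cl` gives 20000 nM in the same test. Compound 2 therefore stands level with compound 1, and compound 3 lies within the usual scatter of both, so the three numbers show no real spread.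

Compound 4 `Fc1ccc(NC(=S)Nc2cccc(C(F)(F)F)c2)cc1` has not been measured yet. It differs from compound 2 by fluoro in place of cyano on an aromatic carbon, a single swap fluoro in place of cyano on an aromatic carbon on one ring. For the measured compounds named here, only one measured step changes a single group at this carbon, which makes the evidence thin. Since cyano in place of nitro gave no change at the digits printed from compound 1 to compound 2 (within the scatter) as its whole effect, no step beyond the scatter is expected in this assay for this swap, and no clear direction either. The estimated step is a 1.5-fold higher number from compound 2 to compound 4 (0.18 log units; within the scatter) and it stays within the scatter. For compound 4 the estimate is 15000 nM with an expected range from 6000 nM to 40000 nM in repeated measurements.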

Compound 4, half-maximal cytotoxic concentration: 40000 nM
Compound 4: middle estimate off by 2.7-fold (0.43 log units), on the low side; the range from low to high includes it.
By their numbers in this assay, from the lowest: compounds 1, 2, 3 and 4 (each within the scatter of the next, the first and the last beyond it).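

In this assay this carbon proves able to move the number: fluoro in place of cyano gives a 4.0-fold higher number from compound 2 to compound 4 (0.60 log units; beyond the scatter) and fluoro in place of nitro gives a 4.0-fold higher number from compound 1 to compound 4 (0.60 log units; beyond the scatter) on the same shared core. For the compounds shown here, until now, the only swap at this carbon, cyano in place of nitro, had stayed within the scatter, so these are the first steps here that go beyond it, both towards lower toxicity in this test. Nothing measured alongside these compounds explains the change.

The compounds shown leave open whether fluoro is unusual here or whether a methoxy group or an amine on this carbon would give a similar step. As far as these compounds go, it also remains open whether the step would keep its size if the trifluoromethyl group on the shared core were replaced by another group.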